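Lengthening the Unsaturated Amide Chain From Compound 3 to Compound 4

The source may hold more compounds than are shown below. What is called first, only, known or untested is meant among the compounds shown, and "the series" means these compounds.

Three compounds sharing one core were tested in a functional assay on A549 cells (Homo sapiens) for inhibition, read by MTT assay, with a stated time of 72 h; a lower number here means a stronger inhibitor, a higher number a weaker inhibitor. Compound 1 `C/C=C/C(=O)Nc1cccc(Oc2nc(Nc3cccc(OC)c3)nc3ccsc23)c1` gives 10500 nM. Compound 2 `COc1cccc(Nc2nc(Oc3cccc(NC(=O)C=C(C)C)c3)c3sccc3n2)c1` gives 27700 nM, and compound 3 `CC/C=C/C(=O)Nc1cccc(Oc2nc(Nc3cccc(OC)c3)nc3ccsc23)c1` gives 19600 nM. The number for compound 3 sits amid the other two, and both gaps lie within the scatter: a 1.9-fold higher number from compound 1 to compound 3 (0.27 log units; within the scatter), and a 1.4-fold lower number from compound 2 to compound 3 (0.15 log units; within the scatter). Compound 4 `CCC/C=C/C(=O)Nc1cccc(Oc2nc(Nc3cccc(OC)c3)nc3ccsc23)c1` differs from compound 3 by methyl in place of hydrogen on a saturated chain carbon, two bonds along the chain from a double-bonded chain carbon, so the chain grows by one carbon. Among the compounds with values here, the closest precedent is the earlier chain extension, a 1.9-fold higher number from compound 1 to compound 3 (0.27 log units; within the scatter), which stayed within the scatter. A similarly small shift is therefore expected in this assay, a 1.3-fold higher number from compound 3 to compound 4 (0.12 log units; within the scatter). Compound 4 is expected to give about 26000 nM, with a range of 10000 nM to 65000 nM.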

Compound 4, half-maximal inhibitory concentration: 5560 nM
Compound 4: middle estimate off by 4.7-fold (0.67 log units), on the high side; the whole stated range lies above it.
By their numbers in this assay, from the lowest: compounds 4, 1, 3 and 2 (each within the scatter of the next, the first and the last beyond it).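

One more carbon on the but-1-en-1-yl chain gives a step beyond the scatter (a 3.5-fold lower number from compound 3 to compound 4 (0.55 log units; beyond the scatter)), so this position responds to chain length, and not in the small way the earlier extension suggested. The pent-1-en-1-yl chain also stands clearly apart from the branched chain of compound 2 (a 5.0-fold lower number from compound 2 to compound 4 (0.70 log units; beyond the scatter)), a gap that compound 3 did not show. Against the shorter chain of compound 1, however, the step stays within the scatter (a 1.9-fold lower number from compound 1 to compound 4 (0.28 log units; within the scatter)).

No evidence shown accounts for this uneven response to chain length. Going by these compounds, whether a longer chain, such as hex-1-en-1-yl, or an amine at the chain end would hold this value remains open.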